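The source may report more compounds than this note shows. Statements on the series, on what has been measured and on what is new or still open speak of the compounds shown alone.

Working notes on the sulfonylurea and sulfonylcarbamate series.

Compound 1 `CCCN(CCC)S(=O)(=O)NC(=O)Nc1c(C(C)C)cccc1C(C)C` gives 1100 nM in an assay on liver for inhibition of sterol O-acyltransferase 1 (Rattus norvegicus), using microsomes; a higher number here means a weaker inhibitor, a lower number a stronger inhibitor. Compound 2 `CC(C)c1cccc(C(C)C)c1OC(=O)NS(=O)(=O)N1CCCCC1` reaches only the assay limit in this assay, > 100000 nM (the limit of > 100000 nM in this assay, at which 1 of the 3 values shown sits). Compound 3 `Cc1cc(C(C)(C)C)c(OC(=O)NS(=O)(=O)N(C(C)C)C(C)C)c(C(C)(C)C)c1` gives 3200 nM in this assay, the higher of the two numbers reported; compound 1 sits beyond the scatter from it.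

Compound 4 `CCCCCCOS(=O)(=O)NC(=O)Oc1c(C(C)(C)C)cc(C)cc1C(C)(C)C` carries hexyloxy in place of diisopropylamino on a sulfonyl sulfur. Within the data shown here, no measured step mirrors this change, so the direction is open. In this assay the step from compound 3 to compound 4 is expected to be a 1.4-fold higher number from compound 3 to compound 4 (0.15 log units; within the scatter), a modest move that may not clear the scatter. Compound 4 is therefore estimated at 4500 nM in this assay, with a range from 1200 nM to 18000 nM.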

Compound 4, half-maximal inhibitory concentration: 95000 nM
Beside the measured number, compound 4's estimate is 21-fold (1.32 log units) below it; measured number outside the range, above it.
By their numbers in this assay, from the lowest: compound 1; then compound 3; then compound 4. At a limit, above all of these: compound 2.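

The sulfonyl sulfur position is sensitive to this swap, with a 30-fold higher number from compound 3 to compound 4 (1.47 log units; beyond the scatter) in this assay. Hexyloxy and diisopropylamino each have 7 heavy atoms and no ring, so matching the heavy-atom count does not preserve the value at this position. No measurement shown accounts for the size of this step.

From the compounds shown here alone, whether the loss follows the oxygen link or the hexyl chain remains open. A hexylamino group on the same sulfur would separate these two changes.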